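This account rests on a few compounds, and the source may have more. Where it says the series, first, only, none or still open, it means among the compounds named here.

Measured compounds:
compound 1 `CN(CCC#N)C[C@H]1CN(c2ccc(-n3cc(-c4ccccn4)cn3)c(F)c2)C(=O)O1` — > 400 ug/mL
compound 2 `O=C1O[C@@H](CN2CCCCC2)CN1c1ccc(-n2cc(-c3ccccn3)cn2)c(F)c1` — > 400 ug/mL

In an ADME assay on HEK293-A cells (Homo sapiens) for cytotoxicity, read by MTT assay, with a stated time of 48 h (a higher number here means a weaker inhibitor, a lower number a stronger inhibitor), compound 1 gives > 400 ug/mL, a limit of the assay rather than a number. Compound 2 likewise gives > 400 ug/mL, again a limit. The step that the two limits leave unreadable from compound 1 to compound 2 therefore cannot be read, because both values sit at the limit described by the limit of > 400 ug/mL in this assay, at which 2 of the 2 values shown sit. Among the measured compounds shown here, compound 2 thus stands where the only other measured compound stands, at a limit, with no number between them to rank.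

Compound 3 `CCC(=O)NC[C@H]1CN(c2ccc(-n3cc(-c4ccccn4)cn3)c(F)c2)C(=O)O1` differs from compound 2 by propanoylamino in place of piperidin-1-yl on a saturated chain carbon bound to a saturated ring carbon. No measured step bears on this change; the one step shown is unreadable. In this assay compound 3 is expected to remain at the limit, so a number no higher from compound 2 to compound 3 (the limit leaves the size open) is expected to be no step beyond the scatter. Compound 3 is estimated at 400 ug/mL, with a range from 200 ug/mL to 800 ug/mL.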

Compound 3, half-maximal inhibitory concentration: 389 ug/mL
The estimate for compound 3 lay 1.0-fold (0.01 log units) above the measured number, within the range that was stated.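

In this assay, among the compounds shown here, compound 3 gives 389 ug/mL, the only value shown at this position that is a number rather than a limit. Propanoylamino, which has no ring and carries a hydrogen-bond donor, gives an at least 1.0-fold lower number from compound 2 to compound 3 (0.01 log units; that floor lies within the scatter), and in the same way an at least 1.0-fold lower number from compound 1 to compound 3 (0.01 log units; that floor lies within the scatter), so neither step is shown to go beyond the scatter. The values for compound 1 and compound 2 are still limits, so these steps give only a floor: the limit of > 400 ug/mL in this assay, at which 2 of the 3 values shown sit.

On these data alone, whether a carboxylic acid, a primary amine or a longer acyl chain on this saturated chain carbon would give a number clearly apart from that of compound 3 remains open. As far as these compounds go, the true size of both steps also remains open, as does whether any group at this position lowers the number beyond the scatter.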